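The source may hold more compounds than are shown below. What is called first, only, known or untested is meant among the compounds shown, and "the series" means these compounds.

Measured compounds:
- compound 1, `Oc1ccc(/C=C/c2cccc(O)c2)cc1`, in a functional assay on MCF7 cells (Homo sapiens) for inhibition, read by MTT assay, with a stated time of 2 days (on this read-out higher numbers stand for weaker inhibition and lower numbers for stronger inhibition), gives 23 ug/mL
- compound 2, `Nc1ccc(/C=C/c2cccc(O)c2)cc1`, in this assay gives 24.8 ug/mL
- compound 3, `COc1cccc(/C=C/c2ccc(O)cc2)c1`, in this assay gives 21 ug/mL

The change from compound 1 to compound 2 is amino in place of hydroxy on an aromatic carbon and made a step of a 1.1-fold higher number from compound 1 to compound 2 (0.03 log units; within the scatter). The same kind of change is made from compound 3 to compound 4, `COc1cccc(/C=C/c2ccc(N)cc2)c1`, which is amino in place of hydroxy on an aromatic carbon; the two places are described a little differently, one as para to a group of 9 heavy atoms and the other as para to a large group. The cores of compound 1 and compound 3 differ by methyl in place of hydrogen on an oxygen on an aromatic ring, a change that gave a step of a 1.1-fold lower number from compound 1 to compound 3 (0.04 log units; within the scatter).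

Since the change from compound 1 to compound 2 stayed within the scatter, compound 4 is expected to sit close to compound 3, with an estimated step of a 1.0-fold higher number from compound 3 to compound 4 (0.02 log units; within the scatter). Compound 4 is therefore estimated to give 22 ug/mL, with a likely range from 12 ug/mL to 42 ug/mL.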

Compound 4, half-maximal inhibitory concentration: 52 ug/mL
Beside the measured number, compound 4's estimate is 2.4-fold (0.37 log units) below it; measured number outside the range, above it.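

In this assay, amino in place of hydroxy on an aromatic carbon gave a 2.5-fold higher number from compound 3 to compound 4 (0.39 log units; beyond the scatter), and set beside the earlier step on the core of compound 1, the gap stays inside what two such steps can scatter: the same change on two cores in this assay, a 1.1-fold higher number (0.03 log units; within the scatter) from compound 1 to compound 2 and a 2.5-fold higher number (0.39 log units; beyond the scatter) from compound 3 to compound 4, 2.3-fold (0.36 log units) apart, within the scatter of two such steps. Methyl in place of hydrogen on an oxygen on an aromatic ring gave a 2.1-fold higher number from compound 2 to compound 4 (0.32 log units; beyond the scatter), and this change reads the same way: the same change on two cores in this assay, a 1.1-fold lower number (0.04 log units; within the scatter) from compound 1 to compound 3 and a 2.1-fold higher number (0.32 log units; beyond the scatter) from compound 2 to compound 4, 2.3-fold (0.36 log units) apart, within the scatter of two such steps. Among the compounds shown here, the four compounds therefore give no firm sign that either change depends on the core, yet with only one pair of steps for each change they do not show that it carries over unchanged either.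

The compounds shown leave open how a carboxylic acid or a dimethylamino group would read in place of the amino group on these cores, and whether a longer chain than methyl on the oxygen would follow the same steps. They also leave open whether either change would behave alike on a third core.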